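Replacing the sulfur-linked purine by a nitrogen-linked one

This account rests on a few compounds, and the source may have more. Where it says the series, first, only, none or still open, it means among the compounds named here.

Measured compounds:
compound 1 , `OC(CSc1[nH]cnc2ncnc1-2)CN1CCN(C(c2ccccc2)c2ccccc2)CC1`, 249%
compound 2 , `Nc1nc(SCC(O)CN2CCN(C(c3ccc(F)cc3)c3ccc(F)cc3)CC2)c2[nH]cnc2n1`, 74%

In a functional assay on muscle tissue (Mustela putorius furo) (on this read-out higher numbers stand for larger maximal responses and lower numbers for smaller maximal responses), compound 1 gives 249%. Compound 2 gives 74%, the lowest of the two numbers; compound 1 stands higher by an amount well beyond the scatter. Compound 3 , `OC(CNc1[nH]cnc2ncnc1-2)CN1CCN(C(c2ccc(F)cc2)c2ccc(F)cc2)CC1`, has not yet been measured. It differs from compound 2 in one place: a group of 10 heavy atoms (5 carbon, 5 nitrogen; one five-membered aromatic ring with 2 hetero atoms, one six-membered aromatic ring with 2 hetero atoms) in place of a group of 11 heavy atoms (5 carbon, 5 nitrogen, 1 sulfur; one five-membered aromatic ring with 2 hetero atoms, one six-membered aromatic ring with 2 hetero atoms), on a saturated chain carbon, two bonds along the chain from an oxygen on a saturated carbon. Among the measured compounds shown here, no pair of measured compounds differs in a single place, and compound 1 and compound 2 differ in more than one way, so the size of this step cannot be read from the numbers so far. The wide spread between compound 1 and compound 2 leaves room for a sizeable move in either direction. Compound 3 is estimated at 120%, with a range from 50% to 240%. The expected step of a number 46 percentage points higher from compound 2 to compound 3 (beyond the scatter) is a modest rise, with much uncertainty.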

Compound 3, largest response reached (reported as maximum), in percent of the reference or control that the assay uses: 86%
Compound 3: the middle estimate sits 34 percentage points above what was measured; low and high end bracket the measured number.
By their numbers in this assay, from the lowest: compound 2; then compound 3; then compound 1.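

In this assay, among the compounds shown here, putting the group of 10 heavy atoms (5 carbon, 5 nitrogen) in place of the group of 11 heavy atoms (5 carbon, 5 nitrogen, 1 sulfur) on a saturated chain carbon gives a number 12 percentage points higher from compound 2 to compound 3 (beyond the scatter) and is the first step that can be read at this position. The step is modest, so this change at this position, two bonds along the chain from an oxygen on a saturated carbon, shifts the maximal response only a little. Nothing at hand explains the direction or the size of this step.

The compounds shown do not say how much of the step goes with the loss of the sulfur and how much with the rest of the group. They also leave open how a longer chain or a methoxy group at this position would read in this assay, as the position has so far been probed by this one step.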